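Aryl sulfonyl variation on the shared core: step to compound 4

The source may report more compounds than this note shows. Statements on the series, on what has been measured and on what is new or still open speak of the compounds shown alone.

Measured so far:
- Compound 1, `COc1cc2nc(N3CCN(S(=O)(=O)c4ccc(Br)cc4)CC3)nc(N)c2cc1OC`: 20000 nM
- Compound 2, `COc1cc2nc(N3CCN(S(=O)(=O)c4cccc(C(=O)O)c4)CC3)nc(N)c2cc1OC`: 53000 nM
- Compound 3, `COc1cc2nc(N3CCN(S(=O)(=O)c4ccc(N)cc4N)CC3)nc(N)c2cc1OC`: 67000 nM

In a functional assay on PC-3 cells (Homo sapiens) for inhibition (on this read-out lower numbers stand for stronger inhibition and higher numbers for weaker inhibition), compound 1 stands lowest of the three numbers. The nearest to it is compound 2, with a 2.7-fold higher number from compound 1 to compound 2 (0.42 log units; beyond the scatter). The furthest is compound 3, with a 3.4-fold higher number from compound 1 to compound 3 (0.53 log units; beyond the scatter). Between compound 2 and compound 3 the gap is a 1.3-fold higher number from compound 2 to compound 3 (0.10 log units; within the scatter).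

Compound 4, `COc1cc2nc(N3CCN(S(=O)(=O)c4cc(C(=O)O)c(Cl)cc4Cl)CC3)nc(N)c2cc1OC`, has not yet been tested. Relative to compound 1 the change is 5-carboxy-2,4-dichlorophenyl in place of 4-bromophenyl on a sulfonyl sulfur. The step from compound 1 to compound 2 bears on it directly, since a carboxy group on the ring enters there too, and that step raised the number beyond the scatter. For the measured compounds named here, no measured compound carries a chloro substituent on this ring, so that part of the change is unsampled. The expectation is therefore a modest rise in this assay from compound 1, in the direction seen with compound 2, with wide uncertainty.

Compound 4 is expected to give about 40000 nM in this assay, within 15000 nM to 110000 nM.

The step this estimate means is expected to be a 2.0-fold higher number from compound 1 to compound 4 (0.30 log units; within the scatter).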

Compound 4, half-maximal inhibitory concentration: 52000 nM
Compound 4: the middle estimate sits 1.3-fold (0.11 log units) below what was measured; the measured number falls inside the stated range.
By their numbers in this assay, from the lowest: compound 1; then compounds 4, 2 and 3 (each within the scatter of the next).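

In this assay, a 2.6-fold higher number from compound 1 to compound 4 (0.41 log units; beyond the scatter), so a ring carrying both carboxy and chloro substituents also stays on the weaker side of the 4-bromophenyl group. Nothing separates the three other rings: a 1.0-fold lower number from compound 2 to compound 4 (0.01 log units; within the scatter), and a 1.3-fold lower number from compound 3 to compound 4 (0.11 log units; within the scatter), so the two chloro substituents on the carboxy-bearing ring leave no readable mark on the number here. No evidence is available that explains these steps.

Open, as far as these compounds go, is whether a 2,4-dichlorophenyl ring without the carboxylic acid would sit with compound 1 or with compound 4, which would separate the chloro contribution from that of the acid. Also open, from the compounds shown here alone, is whether a methyl ester in place of the carboxylic acid would change the number for compound 4.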